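A few compounds are considered here, and "the series" means these few. Any claim that something is new, unique, unknown or untested is made for them only; others in the source may bear on it.

Compound 1 `COc1ccc(CN(C(=O)CSc2ccccn2)c2cc(OC)c(OC)c(OC)c2)cc1` gives 16000 nM in a functional assay on ECa-109 cells for antiproliferative activity against ECa-109 cell line (Homo sapiens), read by MTT assay, with a stated time of 48 h; a higher number here means a weaker inhibitor, a lower number a stronger inhibitor; compound 2 `COc1ccc(CN(C(=O)CCSc2nc3ccccc3o2)c2cc(OC)c(OC)c(OC)c2)cc1` gives 12600 nM.

Compound 2 holds the lower of the two numbers, yet its nearest neighbour is compound 1 and the step of a 1.3-fold lower number from compound 1 to compound 2 (0.10 log units; within the scatter) falls within the scatter. Compound 3 `COc1ccc(CN(C(=O)CSc2nc3ccccc3o2)c2cc(OC)c(OC)c(OC)c2)cc1` differs from compound 2 by (1,3-benzoxazol-2-yl)sulfanyl in place of ((1,3-benzoxazol-2-yl)sulfanyl)methyl on a saturated chain carbon bound to a carbonyl carbon. Among the compounds with values here, the single measured step, a 1.3-fold lower number from compound 1 to compound 2 (0.10 log units; within the scatter), swaps one whole sulfanyl group for another and so does not isolate this difference; it was small. No step beyond the scatter is therefore expected, in either direction. Compound 3 is estimated at 13000 nM, between 6000 nM and 30000 nM, the expected step being a 1.0-fold higher number from compound 2 to compound 3 (0.01 log units; within the scatter).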

Compound 3, half-maximal inhibitory concentration: 24800 nM
Beside the measured number, compound 3's estimate is 1.9-fold (0.28 log units) below it; measured number inside the range.
By their numbers in this assay, from the lowest: compounds 2, 1 and 3 (each within the scatter of the next).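

In this assay, within the data shown here, the change to (1,3-benzoxazol-2-yl)sulfanyl from ((1,3-benzoxazol-2-yl)sulfanyl)methyl on a saturated chain carbon bound to a carbonyl carbon gives a 2.0-fold higher number from compound 2 to compound 3 (0.29 log units; within the scatter) and so reads this chain difference on its own for the first time, with no shift beyond the scatter. With the chain held the same, 1,3-benzoxazol-2-yl in place of pyridin-2-yl on a sulfur gives a 1.6-fold higher number from compound 1 to compound 3 (0.19 log units; within the scatter) and also stays within the scatter.

As far as these compounds go, whether an amine, a carboxylic acid or a longer chain in place of these sulfanyl groups would move the number beyond the scatter remains open. Nothing available here bears on a cause for either step.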